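The source may hold more compounds than are shown below. What is called first, only, known or untested is meant among the compounds shown, and "the series" means these compounds.

Series notes in a physicochemical assay for solubility, read by turbidimetry, in phosphate buffer, with a stated time of 24 h, at pH 7.4; a higher number here means a more soluble compound, a lower number a less soluble compound:
- compound 1 `CCNC(=O)Nc1nc2cc(-c3cccnc3)cc(-c3ccccn3)c2s1` gives 6.25 ug/mL.
- compound 2 `CCNC(=O)Nc1nc2cc(-c3cnc(N4CCC(C(=O)O)CC4)nc3)cc(-c3ccccn3)c2s1` gives > 800 ug/mL, a limit of the assay.
- compound 3 `CCNC(=O)Nc1nc2cc(-c3ccc(N4CCC(C)(C(=O)O)CC4)nc3)cc(-c3ccccn3)c2s1` gives > 800 ug/mL, a limit of the assay.

Compound 2 thus stands at the limit of this assay, as the limit of > 800 ug/mL in this assay, at which 2 of the 3 values shown sit, records. Among the measured compounds shown here, the one step measured with a number on both sides, an at least 120-fold higher number from compound 1 to compound 3 (2.10 log units; beyond the scatter), carries a compound up to that same limit. Compound 4 `CCNC(=O)Nc1nc2cc(-c3cnc(N4CCCC(C)(C(=O)O)CC4)nc3)cc(-c3ccccn3)c2s1` differs from compound 2 by 4-carboxy-4-methylazepan-1-yl in place of 4-carboxypiperidin-1-yl on an aromatic carbon. For the measured compounds named here, no measured step covers this particular change; the carboxy group appears in both names. With compound 2 at the limit, the expectation for compound 4 is no step beyond the scatter, a number no higher from compound 2 to compound 4 (the limit leaves the size open), and its solubility is estimated at 800 ug/mL (range 300 ug/mL to 1600 ug/mL), most likely reported again only as a limit.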

Compound 4, solubility: > 800 ug/mL
Compound 4 gave a limit, no number (the forecaster's own chance of this, stated with the estimate: 70%); the middle value sits exactly at the limit.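

Compound 2 and compound 4 both stand only as limits, and the step between them cannot be read. The compounds shown leave open whether 4-carboxy-4-methylazepan-1-yl in place of 4-carboxypiperidin-1-yl changes solubility at all.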